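Cyano for Methyl on an Ester Chain: Cytotoxicity Outlook

The source may report more compounds than this note shows. Statements on the series, on what has been measured and on what is new or still open speak of the compounds shown alone.

Measured so far:
compound 1 `Cn1c(=O)c(CCO)c(-c2ccccc2Cl)c2cc(Cl)ccc21` — 34000 nM
compound 2 `CCC(=O)OCCc1c(-c2ccccc2Cl)c2cc(Cl)ccc2[nH]c1=O` — 95000 nM

Of the compounds shown here, two have been tested in an ADME assay on HepG2 2.2.15 cells (Homo sapiens) for cytotoxicity; a lower number here means that less compound is tolerated, a higher number that more compound is tolerated. Compound 1 gives 34000 nM, while compound 2 gives 95000 nM. Compound 2 therefore holds the highest number of the two, and its gap to compound 1 lies beyond the usual scatter of this assay, so compound 2 is the better tolerated of the pair on these numbers.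

Compound 3 `N#CCC(=O)OCCc1c(-c2ccccc2Cl)c2cc(Cl)ccc2[nH]c1=O` is the next compound to be measured. It differs from compound 2 in one place only: cyano in place of methyl on a saturated chain carbon bound to a carbonyl carbon.

For the measured compounds named here, no step between two measured compounds resembles this change, so there is no direct guide to its size. The shared core stays untouched, and the change sits on the ester chain at the far end from the core. In the absence of any comparable step, the expected change in this assay from compound 2 to compound 3 is none beyond the scatter, that is a 1.2-fold lower number from compound 2 to compound 3 (0.07 log units; within the scatter).

For compound 3 the expected value in this assay is 80000 nM, with a range from 30000 nM to 200000 nM.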

Compound 3, half-maximal cytotoxic concentration: 100000 nM
Estimate against measurement, compound 3: 1.3-fold (0.10 log units) below; measured number inside the range.
By their numbers in this assay, from the lowest: compound 1; then compounds 2 and 3 (each within the scatter of the next).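

In this assay, cyano in place of methyl on a saturated chain carbon bound to a carbonyl carbon gives a 1.1-fold higher number from compound 2 to compound 3 (0.02 log units; within the scatter) and so leaves tolerance in these cells unchanged within the usual scatter. For the compounds shown here, this is the first step between two measured compounds that differ in one place, and it shows that this chain carbon accepts the exchange of methyl for cyano, which also brings in a triple bond and a hydrogen-bond acceptor, with no readable shift in this read-out. Nothing measured here explains why the two compounds read alike.

On these data alone, this single step covers only one replacement at one place, so it remains open whether an amine, a carboxylic acid or a longer chain on the same carbon would also stay within the scatter. It also leaves open whether cyano for methyl would read the same way on a compound with a different core or with a different link to the chain.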